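Benzyl change from compound 2 to compound 4

This account rests on a few compounds, and the source may have more. Where it says the series, first, only, none or still open, it means among the compounds named here.

In a functional assay on BT-474 cells (Homo sapiens) for inhibition, read by MTT assay, with a stated time of 5 days (on this read-out lower numbers stand for stronger inhibition and higher numbers for weaker inhibition), compound 1 (`Cc1cc(Nc2nc(NCc3ccccc3F)nc3[nH]ncc23)n[nH]1`) gives 13200 nM, compound 2 (`Cc1cc(Nc2nc(NCc3ccccc3Br)nc3[nH]ncc23)n[nH]1`) gives 10100 nM and compound 3 (`Cc1cc(Nc2nc(NCc3cccc(Cl)c3)nc3[nH]ncc23)n[nH]1`) gives 12900 nM. Compound 2 therefore stands level with the other two, since all three values lie within the scatter of one another. Compound 4 (`Cc1cc(Nc2nc(NCc3ccc(F)cc3)nc3[nH]ncc23)n[nH]1`) has not yet been measured. The structural change is 4-fluorophenyl in place of 2-bromophenyl on a saturated chain carbon bound to a nitrogen on an aromatic ring. The same difference reads 2-bromobenzyl to 4-fluorobenzyl.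

Among the compounds with values here, three measured steps bear on this change. Bromo in place of fluoro on the aromatic ring gives a 1.3-fold lower number from compound 1 to compound 2 (0.12 log units; within the scatter). Replacing 2-bromophenyl with 3-chlorophenyl gives a 1.3-fold higher number from compound 2 to compound 3 (0.11 log units; within the scatter), and replacing 2-fluorophenyl with 3-chlorophenyl gives a 1.0-fold lower number from compound 1 to compound 3 (0.01 log units; within the scatter). All three steps are small and within the scatter. Within the data shown here, none of the measured compounds carries the 4-fluorophenyl group, so this case is an extrapolation from the three compounds and carries a wide range. On these steps, no change beyond the scatter is expected in this assay. The expected step is a 1.2-fold higher number from compound 2 to compound 4 (0.07 log units; within the scatter), which is an estimate and not a measured difference. For compound 4 the estimated value is 12000 nM, with an expected range from 6000 nM to 24000 nM.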

Compound 4, half-maximal inhibitory concentration: 8750 nM
Beside the measured number, compound 4's estimate is 1.4-fold (0.14 log units) above it; the range from low to high includes it.
By their numbers in this assay, from the lowest: compounds 4, 2, 3 and 1 (each within the scatter of the next).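

In this assay, 4-fluorophenyl in place of 2-bromophenyl on the saturated chain carbon bound to a nitrogen on an aromatic ring stays within the scatter (the step is a 1.2-fold lower number from compound 2 to compound 4 (0.06 log units; within the scatter)), and the same holds for 4-fluorophenyl in place of 3-chlorophenyl (a 1.5-fold lower number from compound 3 to compound 4 (0.17 log units; within the scatter)). Within the data shown here, the comparison of 2-fluorophenyl with 4-fluorophenyl is the first in which the same halogen changes its place on the phenyl ring, and that change also stays within the scatter (a 1.5-fold lower number from compound 1 to compound 4 (0.18 log units; within the scatter)), so all four halogen-bearing phenyl groups now read as level in this assay. Nothing measured in these notes accounts for how closely these values agree.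

From the compounds shown here alone, all four compounds carry a single halogen on a phenyl ring, so it remains open whether any other kind of group at this place, such as an amine, a carboxylic acid or a longer chain in place of the benzyl, would move the number beyond the scatter. Going by these compounds, the shared core is also the same throughout, so the effect of a change elsewhere in the molecule remains open as well.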